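A few compounds are considered here, and "the series" means these few. Any claim that something is new, unique, unknown or untested is made for them only; others in the source may bear on it.

Measured in a functional assay on PC-3 cells (Homo sapiens) for cytotoxicity, read by MTT assay; a higher number here means a weaker inhibitor, a lower number a stronger inhibitor:
- Compound 1 `COc1ccc2cc([C@H](C)c3nnc(SCc4c(C)cc(C)cc4C)n3-c3cccc(Cl)c3)ccc2c1`: 16300 nM
- Compound 2 `COc1ccc(CSc2nnc([C@@H](C)c3ccc4cc(OC)ccc4c3)n2-c2ccc(Cl)cc2)cc1`: <= 400000 nM
- Compound 3 `COc1ccc2cc([C@H](C)c3n[nH]c(=S)n3-c3cccc(Cl)c3)ccc2c1`: "not determined" (no result reported)

Compound 2 has no single number, and its entry of <= 400000 nM is a limit of the assay. Its whole standing on these data is the limit of <= 400000 nM in this assay, at which 1 of the 3 values shown sits. Compound 3 adds no number to compare with, so compound 1 alone offers a firm reading, at 16300 nM. Whether compound 2 is stronger or weaker than compound 1 cannot be told from what has been reported.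

Compound 4 `COc1ccc2cc([C@H](C)c3nnc(SCc4ccc(C)cc4)n3-c3ccc(Cl)cc3)ccc2c1` changes compound 2 in one place: methyl in place of methoxy on an aromatic carbon. This puts methyl in place of methoxy on an aromatic carbon, so that 4-methoxybenzyl becomes 4-methylbenzyl, para to a large group. Within the data shown here, no measured pair here shows what this swap does in this assay. The best guide is therefore compound 1 at 16300 nM, a real number from a close relative, and this points to a sizeable move towards a lower number, meaning a stronger inhibitor. The estimated change is a step that the limit leaves unreadable from compound 2 to compound 4, and it is expected to be loose, since it starts from a limit. For compound 4 the expected value is 40000 nM, with an estimated range of 6000 nM to 300000 nM.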

Compound 4, half-maximal inhibitory concentration: 8400 nM
The estimate for compound 4 lay 4.8-fold (0.68 log units) above the measured number; the measured number falls inside the stated range.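

The change from compound 2 to compound 4 cannot be sized in this assay, because compound 2 carries a limit of the assay rather than a single number: the limit of <= 400000 nM in this assay, at which 1 of the 4 values shown sits.

Left open is what putting methyl in place of methoxy does in this assay when both compounds of a pair carry single numbers.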